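Aryl swap on the triazole nitrogen of a spirooxindole series

This account rests on a few compounds, and the source may have more. Where it says the series, first, only, none or still open, it means among the compounds named here.

Compound 2 `N#CC1=C(N)Oc2c(c3nc4ccccc4nc3c3ccccc23)C12C(=O)N(Cc1cnnn1-c1ccccc1Br)c1ccccc12` sits at the limit of a functional assay on A549 cells (Homo sapiens) for antiproliferative activity, read by MTT assay, with a stated time of 48 h (a higher number here means a weaker inhibitor, a lower number a stronger inhibitor), where it gives > 50000 nM, a limit rather than a number. Compound 1 `Cc1ccccc1-n1nncc1CN1C(=O)C2(C(C#N)=C(N)Oc3c2c2nc4ccccc4nc2c2ccccc32)c2ccccc21` likewise gives only a limit in this assay, namely > 50000 nM. Compound 3 `CCOc1ccc(-n2nncc2CN2C(=O)C3(C(C#N)=C(N)Oc4c3c3nc5ccccc5nc3c3ccccc43)c3ccccc32)cc1` gives 25200 nM in this assay, so the steps of an at least 1.9-fold lower number from compound 2 to compound 3 (0.29 log units; that floor lies within the scatter) and an at least 1.9-fold lower number from compound 1 to compound 3 (0.29 log units; that floor lies within the scatter) are floors that lie within the scatter, while the step that the two limits leave unreadable from compound 1 to compound 2 cannot be read, as the limit of > 50000 nM in this assay, at which 2 of the 3 values shown sit, shows. Compound 4 `N#CC1=C(N)Oc2c(c3nc4ccccc4nc3c3ccccc23)C12C(=O)N(Cc1cnnn1-c1ccc(N)cc1)c1ccccc12` arises from compound 2 by 4-aminophenyl in place of 2-bromophenyl on an aromatic nitrogen. For the measured compounds named here, the step from compound 2 to compound 3 is the one measured step that bears on this change, and it fixes no size beyond the scatter. The step of an at least 1.6-fold lower number from compound 2 to compound 4 (0.22 log units; that floor lies within the scatter) is accordingly expected to be small, if any. Compound 4 is expected to give 30000 nM in this assay, between 10000 nM and 100000 nM, with a fair chance that only a limit is again reported.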

Compound 4, half-maximal inhibitory concentration: > 50000 nM
Compound 4: a limit, no number; the forecaster's own chance of this, stated with the estimate: 50%; middle value at least 1.6-fold (0.22 log units) away from the limit.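

Compound 4 gives > 50000 nM in this assay, a limit and not a number. Amino in place of ethoxy on the aromatic carbon gives an at least 1.9-fold higher number from compound 3 to compound 4 (0.29 log units; that floor lies within the scatter), a floor that does not separate the two compounds, and compound 3 remains the only one with a number. The steps from compound 1 and compound 2 to compound 4 cannot be read, because both ends are limits: the limit of > 50000 nM in this assay, at which 3 of the 4 values shown sit.

Open, on these data alone, is whether any aryl group on this nitrogen, such as 4-butoxyphenyl or 4-carboxyphenyl, gives a step beyond the scatter.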